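Anilide series: para substituent on the sulfonyl phenyl

The source may hold more compounds than are shown below. What is called first, only, known or untested is meant among the compounds shown, and "the series" means these compounds.

Three analogues of the shared core have been measured in a functional assay on 143B cells (Homo sapiens) for antiproliferative activity, read by MTT assay, with a stated time of 48 h; on this read-out higher numbers stand for weaker inhibition and lower numbers for stronger inhibition. Compound 1 `O=C(Nc1cccc(/C=C/C(=O)c2nc3ccccc3[nH]2)c1)c1ccccc1` gives 8340 nM, compound 2 `Cc1ccccc1C(=O)Nc1cccc(/C=C/C(=O)c2nc3ccccc3[nH]2)c1` gives 8290 nM and compound 3 `O=C(/C=C/c1cccc(NS(=O)(=O)c2ccc(Cl)cc2)c1)c1nc2ccccc2[nH]1` gives 7450 nM. All three sit within the scatter of one another: a 1.1-fold lower number from compound 1 to compound 3 (0.05 log units; within the scatter) and a 1.1-fold lower number from compound 2 to compound 3 (0.05 log units; within the scatter), so compound 3 cannot be set apart from the rest. Compound 4 `Cc1ccc(S(=O)(=O)Nc2cccc(/C=C/C(=O)c3nc4ccccc4[nH]3)c2)cc1` differs from compound 3 by methyl in place of chloro on an aromatic carbon. The step that bears most directly on it is a 1.0-fold lower number from compound 1 to compound 2 (0.00 log units; within the scatter), a methyl added to an aromatic carbon without effect; the swaps on the amide nitrogen were equally flat. No step beyond the scatter is therefore expected in this assay, a 1.0-fold higher number from compound 3 to compound 4 (0.00 log units; within the scatter). Compound 4 is estimated at 7500 nM, between 4000 nM and 14000 nM.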

Compound 4, half-maximal inhibitory concentration: 3220 nM
Compound 4: middle estimate off by 2.3-fold (0.37 log units), on the high side, and the stated range ends above it.
By their numbers in this assay, from the lowest: compound 4; then compounds 3, 2 and 1 (each within the scatter of the next).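

In this assay, for the compounds shown here, 4-methylphenyl in place of 4-chlorophenyl gives the first step beyond the scatter, a 2.3-fold lower number from compound 3 to compound 4 (0.36 log units; beyond the scatter). The (4-methylphenyl)sulfonyl group also separates compound 4 from both amides, with a 2.6-fold lower number from compound 2 to compound 4 (0.41 log units; beyond the scatter) and a 2.6-fold lower number from compound 1 to compound 4 (0.41 log units; beyond the scatter), a separation that the (4-chlorophenyl)sulfonyl group did not give. This aromatic carbon therefore responds to the swap of chloro for methyl, a modest change but the only one here that can be read.

No measurement at hand accounts for this step. Going by these compounds, whether the lower number is particular to methyl stays open, as does the outcome with methoxy, an amine or a longer chain on the same carbon.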